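This account rests on a few compounds, and the source may have more. Where it says the series, first, only, none or still open, it means among the compounds named here.

Of the compounds shown here, three built on the shared core have been tested in a functional assay on A-375 cells (Homo sapiens) for antiproliferative activity; on this read-out lower numbers stand for stronger inhibition and higher numbers for weaker inhibition. Compound 1 `CCCO/N=C/c1c(N)ncnc1Oc1ccc2[nH]c(C)cc2c1F` gives 28 nM. Compound 2 `CNCCO/N=C/c1c(N)ncnc1Oc1ccc2[nH]c(C)cc2c1F` gives 345 nM. Compound 3 `Cc1cc2c(F)c(Oc3ncnc(N)c3/C=N/OCc3ccccc3)ccc2[nH]1` gives 62 nM, which places compound 3 second highest of the three numbers: the nearest is compound 1, with a 2.2-fold higher number from compound 1 to compound 3 (0.35 log units; beyond the scatter), and the furthest is compound 2, with a 5.6-fold lower number from compound 2 to compound 3 (0.75 log units; beyond the scatter).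

Compound 4 `Cc1cc2c(F)c(Oc3ncnc(N)c3/C=N/OCCO)ccc2[nH]1` has not yet been measured. It differs from compound 3 in one place: hydroxymethyl in place of phenyl on a saturated chain carbon bound to an oxygen. The group that enters brings 1 hydrogen-bond donor and 1 hydrogen-bond acceptor to a chain that carried none in compound 3.

Two measured steps speak to this change. The step of a 12-fold higher number from compound 1 to compound 2 (1.09 log units; beyond the scatter) shows what adding a group with a donor and an acceptor at the end of the chain did. The step of a 5.6-fold lower number from compound 2 to compound 3 (0.75 log units; beyond the scatter) shows that a phenyl on the chain carbon bound to the oxygen gave a clearly lower number than a chain carrying such a group. Taken together, a higher number for compound 4 is expected in this assay, though the incoming group is smaller than the one in compound 2, so a step of a 2.9-fold higher number from compound 3 to compound 4 (0.46 log units; beyond the scatter) is estimated. Compound 4 is therefore expected to give about 180 nM, within a range of 70 nM to 600 nM.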

Compound 4, half-maximal inhibitory concentration: 372 nM
Compound 4: middle estimate off by 2.1-fold (0.32 log units), on the low side, within the range that was stated.
By their numbers in this assay, from the lowest: compound 1; then compound 3; then compounds 2 and 4 (each within the scatter of the next).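

In this assay, the chain ending in hydroxymethyl gives a much weaker result than the benzyloxy chain (a 6.0-fold higher number from compound 3 to compound 4 (0.78 log units; beyond the scatter)), so this position does not accept the exchange of phenyl for hydroxymethyl without a clear loss. Hydroxy and methylamino at the chain end cannot be told apart (a 1.1-fold higher number from compound 2 to compound 4 (0.03 log units; within the scatter)), so exchanging one for the other makes no difference that this read-out can resolve. Set against the plain propyl chain, hydroxy in place of methyl gives a large step (a 13-fold higher number from compound 1 to compound 4 (1.12 log units; beyond the scatter)), as methylamino did (a 12-fold higher number from compound 1 to compound 2 (1.09 log units; beyond the scatter)), and among these four compounds the chains ending in hydroxy or methylamino both stand apart from compound 1 and compound 3, with none going against this.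

The compounds shown offer no measured reason for this pattern. Going by these compounds, it remains open whether a methoxy group or a carboxylic acid at the chain end, or a longer chain ending in hydroxy, would stand with compound 4 or nearer to compound 1.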